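This account rests on a few compounds, and the source may have more. Where it says the series, first, only, none or still open, it means among the compounds named here.

Measured so far:
- compound 1 `[O-][S+](Cc1ccccc1)c1nnc(-c2ccccc2O)o1` gives 8000 nM in a functional assay on HUVEC cells (Homo sapiens) for inhibition, read by ELISA; a lower number here means a stronger inhibitor, a higher number a weaker inhibitor
- compound 2 `[O-][S+](Cc1ccccc1)c1nnc(-c2ccccn2)o1` gives 5000 nM in this assay

Within the data shown here, compound 2 carries the lower of the two numbers, but the only step that links it to another compound, a 1.6-fold lower number from compound 1 to compound 2 (0.20 log units; within the scatter), lies within the scatter, so the two compounds cannot be ranked against each other. Compound 3 `[O-][S+](Cc1ccccc1)c1nnc(-c2cccs2)o1` is not yet measured. It differs from compound 2 in one place: thiophen-2-yl in place of pyridin-2-yl on an aromatic carbon. Among the measured compounds shown here, no measured step shows this particular exchange. For the measured compounds named here, the single step available, a 1.6-fold lower number from compound 1 to compound 2 (0.20 log units; within the scatter), shows that swapping one aromatic ring for another at the same position on the shared core left the number within the scatter, and the same is expected here. Compound 3 is therefore estimated to move by a 1.2-fold higher number from compound 2 to compound 3 (0.08 log units; within the scatter) in this assay, a step not expected to exceed the scatter. Compound 3 is expected to give about 6000 nM, with a range from 2500 nM to 15000 nM.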

Compound 3, half-maximal inhibitory concentration: 7000 nM
Compound 3: the middle estimate sits 1.2-fold (0.07 log units) below what was measured; the range from low to high includes it.
By their numbers in this assay, from the lowest: compounds 2, 3 and 1 (each within the scatter of the next).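

Thiophen-2-yl in place of pyridin-2-yl gives a 1.4-fold higher number from compound 2 to compound 3 (0.15 log units; within the scatter) in this assay. Thiophen-2-yl in place of 2-hydroxyphenyl gives a 1.1-fold lower number from compound 1 to compound 3 (0.06 log units; within the scatter) in this assay. This position has now carried a five-membered aromatic ring as well as two six-membered aromatic rings, and all three compounds remain within the scatter of one another, so neither ring size nor the change of hetero atom separates these compounds, and none can be ranked.

All three groups are aromatic rings, so the compounds shown leave open whether an amine, a carboxylic acid or a longer alkyl chain on this carbon would move the number beyond the scatter. No data at hand explain why these three rings give such closely matched numbers.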